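Swapping the Aryl Group Before Cytotoxicity Is Measured

A few compounds are considered here, and "the series" means these few. Any claim that something is new, unique, unknown or untested is made for them only; others in the source may bear on it.

Three compounds share one core and differ only in the aryl group attached to it: compound 1 `N#Cc1c(-c2ccc(Cl)cc2)c(C#N)c(=O)n(/N=C/c2cn(-c3ccccc3)nc2-c2ccccc2)c1N` carries a chloro, compound 2 `Cc1ccc(-c2c(C#N)c(N)n(/N=C/c3cn(-c4ccccc4)nc3-c3ccccc3)c(=O)c2C#N)cc1` a methyl and compound 3 `COc1ccc(-c2c(C#N)c(N)n(/N=C/c3cn(-c4ccccc4)nc3-c3ccccc3)c(=O)c2C#N)cc1` a methoxy on an aromatic carbon. In an ADME assay on HeLa cells (Homo sapiens) for cytotoxicity, read by MTT assay (a higher number here means a weaker inhibitor, a lower number a stronger inhibitor), compound 1 gives > 200 ug/mL, which is a limit of the assay rather than a number. Compound 2 likewise gives > 200 ug/mL, again a limit. Compound 3 gives > 200 ug/mL, also a limit. Hence the steps a step that the two limits leave unreadable from compound 1 to compound 2, a step that the two limits leave unreadable from compound 1 to compound 3 and a step that the two limits leave unreadable from compound 2 to compound 3 cannot be sized; the only evidence is the limit of > 200 ug/mL in this assay, at which 3 of the 3 values shown sit. Compound 4 `N#Cc1c(-c2cccc([N+](=O)[O-])c2)c(C#N)c(=O)n(/N=C/c2cn(-c3ccccc3)nc2-c2ccccc2)c1N`, not yet measured, differs from compound 3 by 3-nitrophenyl in place of 4-methoxyphenyl on an aromatic carbon. Among the compounds with values here, no measured step involves a nitro group, and the three measured steps give no readable size, so no step beyond the scatter is expected in this assay, and the estimated step that the limit leaves unreadable from compound 3 to compound 4 expresses this. For compound 4 the expected value is 250 ug/mL, with a range from 100 ug/mL to 600 ug/mL, most likely again reported only as a limit.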

Compound 4, half-maximal inhibitory concentration: > 200 ug/mL
Compound 4 was reported as a limit (the forecaster's own chance of this, stated with the estimate: 80%); the middle value does not contradict the limit.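

In this assay compound 4 gives > 200 ug/mL, again a limit of the assay and not a number. Its steps from compound 1, compound 2 and compound 3 therefore cannot be read; the only evidence is this: the limit of > 200 ug/mL in this assay, at which 4 of the 4 values shown sit.

The compounds shown leave open whether swapping the aryl group changes cytotoxicity at all, as none of them gives a readable number.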